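This account rests on a few compounds, and the source may have more. Where it says the series, first, only, none or still open, it means among the compounds named here.

Two compounds built on a shared core were tested in a functional assay on RXF 393 cells (Homo sapiens) for cytotoxicity, read by sulforhodamine B assay, with a stated time of 48 h; on this read-out lower numbers stand for stronger inhibition of growth and higher numbers for weaker inhibition of growth. Compound 1 `ClCc1ccc(Cn2cnc3c(Cl)ncnc32)cc1` gives 5490 nM there, and compound 2 `ClCc1cccc(Cn2cnc3c(Cl)ncnc32)c1` gives 24000 nM. Of the two numbers on hand, compound 2 stands at the highest, with compound 1 as its nearest neighbour at a lower number, a gap beyond the scatter. Within the data shown here, no step between two measured compounds is available for the change now considered. Compound 3 `ClCc1cccc(Cn2cnc3c(Cl)nc(Cl)nc32)c1` differs from compound 2 by chloro in place of hydrogen on an aromatic carbon, a chloro in place of hydrogen on an aromatic carbon, at a site between two ring nitrogen atoms. With nothing measured on such a change, the step in this assay is expected to be small, and the estimated step is a 1.6-fold lower number from compound 2 to compound 3 (0.20 log units; within the scatter), without a direction claimed beyond the scatter. Compound 3 is therefore estimated to give 15000 nM in this assay, within a range from 4000 nM to 50000 nM.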

Compound 3, concentration for total growth inhibition: 2090 nM
Compound 3: the middle estimate sits 7.2-fold (0.86 log units) above what was measured; measured number outside the range, below it.
By their numbers in this assay, from the lowest: compound 3; then compound 1; then compound 2.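

The site on an aromatic carbon between two ring nitrogen atoms, which carries hydrogen in compound 1 and compound 2, proves responsive in this assay: chloro in place of hydrogen there gives an 11-fold lower number from compound 2 to compound 3 (1.06 log units; beyond the scatter) and moves the number beyond the scatter. The change that does this is small, a chloro group of 1 heavy atom with no ring and no net charge, so this position cannot be treated as indifferent to substitution. Nothing at hand bears on the reason for this step.

On these data alone, whether the step belongs to chloro itself or would also follow from another group at this site, such as an amine, a methoxy group or a methyl group, remains open. Also open, as far as these compounds go, is whether the same chloro would bring a step of like size on compound 1.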